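Dithiocarbamate benzamide series: working notes on compound 4

This account rests on a few compounds, and the source may have more. Where it says the series, first, only, none or still open, it means among the compounds named here.

Measured so far in a functional assay on A-375 cells (Homo sapiens) for antiproliferative activity, read by CCK-8 assay, with a stated time of 72 h, tested at 2 uM; on this read-out lower numbers stand for a weaker effect and higher numbers for a stronger effect at the one concentration tested:
compound 1 `CCN(Cc1ccncc1)C(=S)SCc1ccc(C(=O)Nc2ccccc2N)cc1` gives 67.2%
compound 2 `CN(Cc1ccncc1)C(=S)SCc1ccc(C(=O)Nc2ccccc2N)cc1` gives 31.4%
compound 3 `Nc1ccccc1NC(=O)c1ccc(CSC(=S)N2CCc3cc(Cl)ccc32)cc1` gives 31.9%

Compound 3 sits second of the three numbers; its gap to compound 2 is within the scatter, while compound 1 lies well above it. Going by these compounds, compound 4 `CN(C(=S)SCc1ccc(C(=O)Nc2ccccc2N)cc1)c1cccnc1` is untested. The change is methyl(pyridin-3-yl)amino in place of 5-chloro-2,3-dihydro-1H-indol-1-yl on a thiocarbonyl carbon.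

Two measured steps alter the same position on the thiocarbonyl carbon: a number 35.3 percentage points lower from compound 1 to compound 3 (beyond the scatter) and a number 0.5 percentage points higher from compound 2 to compound 3 (within the scatter). The first shows that this position can move the read-out a lot; the second shows that swapping one nitrogen substituent for another can also leave it unchanged. Among the measured compounds shown here, no measured step carries the entering group, so the direction is uncertain, and a step of modest size is expected, a number 4.1 percentage points higher from compound 3 to compound 4 (within the scatter). For compound 4 the estimate is 36%, range 15% to 60%.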

Compound 4, a percentage reported as inhibition, at one concentration (the size of the read-out at that concentration, not a potency): 26.5%
The estimate for compound 4 lay 9.5 percentage points above the measured number; measured number inside the range.
By their numbers in this assay, from the lowest: compounds 4, 2 and 3 (each within the scatter of the next); then compound 1.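

In this assay, methyl(pyridin-3-yl)amino on the thiocarbonyl carbon reads like the groups of the two nearest compounds (step: a number 5.4 percentage points lower from compound 3 to compound 4 (within the scatter); a number 4.9 percentage points lower from compound 2 to compound 4 (within the scatter)). Pyridin-3-yl in place of (pyridin-4-yl)methyl thus leaves the number within the scatter, while compound 1 stays apart (step: a number 40.7 percentage points lower from compound 1 to compound 4 (beyond the scatter)). Among these groups, only ethyl((pyridin-4-yl)methyl)amino gives the high number. No measured evidence bears on the cause of this result. Open, going by these compounds, is whether ethyl in place of methyl lifts the number with pyridin-3-yl, and how a morpholine ring on the thiocarbonyl carbon would read.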